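Chain length and gastric inhibition: estimating compound 3

A few compounds are considered here, and "the series" means these few. Any claim that something is new, unique, unknown or untested is made for them only; others in the source may bear on it.

Compound 1 `N=C(S)CCCCCCN1N=C(c2ccccc2)CCC1=O`: 68.3%
Compound 2 `N=C(S)CCN1N=C(c2ccccc2)CCC1=O`: 38.2%

In a functional assay on the whole organism (stomach) for inhibition, with Rattus norvegicus as the target, at a dose of 100 mg/kg by the intraduodenal route (on this read-out lower numbers stand for less inhibition and higher numbers for more inhibition at the one dose given (going by the name of the read-out)), compound 1 gives 68.3%, while compound 2 gives 38.2%, the lowest of the two numbers. For the measured compounds named here, the only known step is a number 30.1 percentage points lower from compound 1 to compound 2 (beyond the scatter), where the smaller group entered. Compound 3 `N=C(S)CCCCCN1N=C(c2ccccc2)CCC1=O` differs from compound 2 by a group of 6 heavy atoms (4 carbon, 1 nitrogen, 1 sulfur; no ring) in place of a group of 3 heavy atoms (1 carbon, 1 nitrogen, 1 sulfur; no ring), on a saturated chain carbon, two bonds along the chain from an amide-type nitrogen in a ring, so the larger group returns, though not as large as in compound 1. Because that step a number 30.1 percentage points lower from compound 1 to compound 2 (beyond the scatter) was large, a rise is expected, by a number 21.8 percentage points higher from compound 2 to compound 3 (beyond the scatter). Compound 3 is estimated at 60%, in the range 42% to 75%.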

Compound 3, a percentage reported as inhibition, in the whole organism at one dose (the size of the read-out at that dose, not a potency): 48.5%
Compound 3: the middle estimate sits 11.5 percentage points above what was measured; the range from low to high includes it.
By their numbers in this assay, from the lowest: compound 2; then compound 3; then compound 1.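

In this assay the new compound splits the chain effect into two steps: a number 10.3 percentage points higher from compound 2 to compound 3 (beyond the scatter) and then a number 19.8 percentage points lower from compound 1 to compound 3 (beyond the scatter) when read from the longest chain back. The three compounds therefore rank in order of chain length, none going against it, and the change is spread over both steps rather than sitting in one jump. No measurement here explains why the longer chains give more inhibition. From the compounds shown here alone, whether a still longer chain would raise the number further, and whether an amine or a carboxylic acid in place of this group would keep the inhibition, stays open.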